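Series notes: chloro in place of (methylsulfanyl)methyl

This account rests on a few compounds, and the source may have more. Where it says the series, first, only, none or still open, it means among the compounds named here.

Measured compounds:
compound 1 `Cc1nc2c(OCc3ccccc3)cccn2c1C(N)=O` gives 2%
compound 2 `Cc1nc2c(OCc3ccccc3)cccn2c1CCC#N` gives 20%
compound 3 `CSCc1c(C)nc2c(OCc3ccccc3)cccn12` gives 8%

In a functional assay on the whole organism (stomach) for inhibition, with Canis familiaris (Canis lupus familiaris) as the target, at a dose of 5 mg/kg by the intravenous route (on this read-out lower numbers stand for a weaker effect and higher numbers for a stronger effect at the one dose given), compound 3 stands second highest of the three numbers. Its nearest neighbour is compound 1, with a number 6 percentage points higher from compound 1 to compound 3 (within the scatter); its furthest is compound 2, with a number 12 percentage points lower from compound 2 to compound 3 (beyond the scatter).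

Compound 4 `Cc1nc2c(OCc3ccccc3)cccn2c1Cl` differs from compound 3 by chloro in place of (methylsulfanyl)methyl on an aromatic carbon. The two steps that touch this same aromatic carbon are the ones above: one within the scatter, one modest. Among the measured compounds shown here, neither brings in a one-atom group, so no step in the data mirrors this change directly. Given that the position has so far moved the numbers only modestly at best, a step within the scatter is expected, a number 2 percentage points lower from compound 3 to compound 4 (within the scatter). Compound 4 is therefore estimated at 6%, with a range from 0% to 18%.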

Compound 4, a percentage reported as inhibition, in the whole organism at one dose (the size of the read-out at that dose, not a potency): 37%
The estimate for compound 4 lay 31 percentage points below the measured number, and the stated range ends below it.
By their numbers in this assay, from the lowest: compounds 1 and 3 (each within the scatter of the next); then compound 2; then compound 4.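

In this assay, among the compounds shown here, this aromatic carbon proves able to move the number far more than the earlier compounds suggested: chloro, with 1 heavy atom, gives a number 29 percentage points higher from compound 3 to compound 4 (beyond the scatter) and a number 17 percentage points higher from compound 2 to compound 4 (beyond the scatter) as well as a number 35 percentage points higher from compound 1 to compound 4 (beyond the scatter) on the same core. Compound 4 therefore stands highest of the four, with all three of its steps beyond the scatter. No measurement at hand accounts for this rise.

Going by these compounds, whether the gain is particular to chloro remains open, since bromo, fluoro or an amine on this carbon would be needed to test it. The compounds shown also leave open whether chloro keeps this standing at other doses.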